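The source may report more compounds than this note shows. Statements on the series, on what has been measured and on what is new or still open speak of the compounds shown alone.

Working notes on the shared core of compound 2 `Cn1c(Cc2nn(C)c(=O)c3ccccc23)nnc1SCCCCCCCCCCC(=O)Nc1ccc(Cl)cc1Cl` in an assay on isolated protein (Mus musculus) for inhibition of IL15-IL15 receptor (Homo sapiens), read by resazurin assay, with stated times of 30 min and 2.5 days; on this read-out higher numbers stand for weaker inhibition and lower numbers for stronger inhibition. Two compounds of the series carry a number: compound 2 gives 3300 nM, and compound 1 `Cn1c(Cc2nn(C)c(=O)c3ccccc23)nnc1SCCCCCCCC(=O)Nc1ccc(F)cc1F` gives 2300 nM; the gap between these two lies within the scatter, so neither can be set above the other. Compound 3 `Cn1c(Cc2nn(C)c(=O)c3ccccc23)nnc1SCC(=O)Nc1ccc(I)cc1` returned no number and is recorded as "not active" (no number reported) in this assay. The next step goes from compound 2 to the unmeasured compound 4 `CCCCCCCCCCSc1nnc(Cc2nn(C)c(=O)c3ccccc23)n1C`, with the change (hydrogen in place of (2,4-dichlorophenyl)carbamoyl on a saturated chain carbon, ten or more bonds along the chain from a sulfur). Among the measured compounds shown here, no measured pair covers this kind of change, so there is no step to lean on. The expectation is a loss, estimated at a 2.7-fold higher number from compound 2 to compound 4 (0.44 log units; beyond the scatter) beyond the scatter, since compound 3, which also lacks a long chain carrying the anilide, gives "not active" (no number reported). Compound 4 is thus expected near 9000 nM, in the range 2500 nM to 35000 nM.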

Compound 4, half-maximal inhibitory concentration: 7600 nM
Beside the measured number, compound 4's estimate is 1.2-fold (0.07 log units) above it; the measured number falls inside the stated range.
By their numbers in this assay, from the lowest: compounds 1 and 2 (each within the scatter of the next); then compound 4.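

In this assay, the carbamoyl end of the chain proves helpful but not essential: hydrogen in place of (2,4-dichlorophenyl)carbamoyl gives a modest loss (a 2.3-fold higher number from compound 2 to compound 4 (0.36 log units; beyond the scatter)). Propyl in place of (2,4-difluorophenyl)carbamoyl likewise gives a modest loss (a 3.3-fold higher number from compound 1 to compound 4 (0.52 log units; beyond the scatter)), so a plain alkyl chain on the sulfur still returns a number. No supporting data explain these steps. Open, as far as these compounds go, is whether a carboxylic acid or an amine at the chain end would match the carbamoyl groups. Compound 1 and compound 2 differ in more than one place, leaving the separate roles of chain length and halogen unresolved.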